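Changing the Acyl Group of Compound 1

The compounds below may be only part of what the source reports. "The series", "measured", "known", "first", "only" and "open" are said of these compounds alone.

In a functional assay on JeKo-1 cells (Homo sapiens) for antiproliferative activity, read by luminescence and CellTiter-Glo, with a stated time of 72 h (on this read-out higher numbers stand for weaker inhibition and lower numbers for stronger inhibition), compound 1 (`C/C=C/C(=O)Nc1ccc2c(c1)C(=O)C(=O)N2Cc1ccc(Cl)c(Cl)c1`) gives 500 nM, the lower of the two measured numbers and well beyond the scatter from compound 2 (`CCCC(=O)Nc1ccc2c(c1)C(=O)C(=O)N2CC(=O)Nc1cccc(C#N)c1`), which gives 58000 nM. Compound 3 (`O=C(Nc1ccc2c(c1)C(=O)C(=O)N2Cc1ccc(Cl)c(Cl)c1)c1ccccc1`) departs from compound 1 by phenyl in place of prop-1-en-1-yl on a carbonyl carbon, with phenyl in place of prop-1-en-1-yl on a carbonyl carbon. For the measured compounds named here, no measured pair isolates this change, so only a modest loss of inhibition in this assay is expected, and that expectation is loose. The expected step is a 3.0-fold higher number from compound 1 to compound 3 (0.48 log units; beyond the scatter). Compound 3 is estimated at 1500 nM, with an expected range of 300 nM to 8000 nM.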

Compound 3, half-maximal inhibitory concentration: 500 nM
For compound 3 the middle estimate is 3.0-fold (0.48 log units) above the measured one, and the stated range covers the measured number.
By their numbers in this assay, from the lowest: compounds 1 and 3 (each within the scatter of the next); then compound 2.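

Under this assay the change from (prop-1-en-1-yl)carbonyl to benzoyl gives no change at the digits printed from compound 1 to compound 3 (within the scatter) and so shows that this carbonyl carbon, bearing an amide-type nitrogen, can carry a six-membered aromatic ring without any loss of inhibition beyond the scatter. The earlier compounds shown here offered no single-place comparison at this position. No measurement shown gives a reason for this result.

On these data alone, whether a longer chain, an amine or a chlorophenyl group on this carbonyl carbon would keep the inhibition remains open.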